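A few compounds are considered here, and "the series" means these few. Any claim that something is new, unique, unknown or untested is made for them only; others in the source may bear on it.

Compound 1 `ClCc1ccc(Cn2cnc3c(Cl)ncnc32)cc1` gives 15900 nM in a functional assay on MDA-MB-435 cells (Homo sapiens) for cytotoxicity, read by sulforhodamine B assay, with a stated time of 48 h; a higher number here means that more compound is tolerated, a lower number that less compound is tolerated. Among the two numbers recorded there it stands highest: compound 2 `ClCc1cccc(Cn2cnc3c(Cl)nc(Cl)nc32)c1` gives 6310 nM, a lower number, and the gap between the two lies beyond the usual scatter. Compound 3 `Nc1nc(Cl)c2ncn(Cc3ccccc3CCl)c2n1` reaches only > 100000 nM, which is a limit of the assay rather than a number.

Compound 4 `Nc1nc(Cl)c2ncn(Cc3ccc(CCl)cc3)c2n1` has not yet been measured in this assay. It differs from compound 1 in one place: amino in place of hydrogen on an aromatic carbon. Going by the values given here, no measured pair shows this exact change, so its effect can only be guessed. Compound 3, which also bears an amino group on its core, sits at the limit of > 100000 nM in this assay, at which 1 of the 3 values shown sits, and that is the one pointer available. A step toward a higher number, one that clears the scatter, is therefore expected from compound 1 to compound 4, with a real chance that only a limit is reported. For compound 4 the value is estimated at 60000 nM, within 20000 nM to 150000 nM, a change of a 3.8-fold higher number from compound 1 to compound 4 (0.58 log units; beyond the scatter).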

Compound 4, concentration lethal to 50% of the cells: > 100000 nM
Compound 4 gave a limit, no number (the forecaster's own chance of this, stated with the estimate: 40%); middle value at least 1.6-fold (0.22 log units) from the limit.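

From the compounds shown here alone, the amino group on the aromatic carbon between two ring nitrogen atoms can now be read directly: in this assay this single change gives an at least 6.2-fold higher number from compound 1 to compound 4 (0.79 log units; beyond the scatter), and the true size of the step remains unknown, since the result for compound 4 is a limit of the assay and not a number. Before this, an amino group on the core had appeared only in compound 3, which differs from compound 1 in more than one place, so the change could not be isolated. Both compounds shown with this amino group now sit at the same limit: the limit of > 100000 nM in this assay, at which 2 of the 4 values shown sit.

Going by these compounds, how far the value of compound 4 lies past that limit stays open. So does whether a methylamino group, a hydroxyl group or a methoxy group in the same place would shift the number as strongly.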